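Bromo in Place of Methoxy: Expectation for Compound 4

A few compounds are considered here, and "the series" means these few. Any claim that something is new, unique, unknown or untested is made for them only; others in the source may bear on it.

Compound 1, `Nc1ccccc1NC(=O)c1ccc(CNC2=N[C@@H](Cc3ccccc3)CS2)cc1`: in an assay on isolated protein for inhibition of protein deacetylase HDAC6 (Homo sapiens), read by fluorescence, with stated times of 3 h and 60 min (on this read-out lower numbers stand for stronger inhibition and higher numbers for weaker inhibition), compound 1 gives > 20000 nM, which is a limit of the assay.
Compound 2, `Nc1ccccc1NC(=O)c1ccc(CNC2=N[C@H](Cc3ccccc3)CS2)cc1`: in this assay compound 2 gives > 20000 nM, again a limit.
Compound 3, `COc1ccc(NC(=O)c2ccc(CNc3nccc(-c4cccnc4)n3)cc2)c(N)c1`: in this assay compound 3 gives > 20000 nM, also a limit.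

Among the compounds with values here, the only pair that differs in one place is compound 1 and compound 2, and their step, a step that the two limits leave unreadable from compound 1 to compound 2, has no readable size because of the limit of > 20000 nM in this assay, at which 3 of the 3 values shown sit. The pair itself rests on (the fact that compounds 1 and 2 differ only in the configuration as drawn). Compound 3 therefore stands where every value shown stands, at a limit, with nothing in the set below it.

Compound 4, `Nc1cc(Br)ccc1NC(=O)c1ccc(CNc2nccc(-c3cccnc3)n2)cc1`, differs from compound 3 by bromo in place of methoxy on an aromatic carbon. Within the data shown here, no measured step covers such a swap, and the one measured step is unreadable, so no direction can be drawn from the data. Compound 4 is expected to sit at or near the limit, with a step that the limit leaves unreadable from compound 3 to compound 4 that is estimated to be none beyond the scatter. For compound 4 the estimated value in this assay is 30000 nM, between 8000 nM and 150000 nM.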

Compound 4, half-maximal inhibitory concentration: > 20000 nM
Compound 4: no number, only a limit; the forecaster's own chance of this, stated with the estimate: 80%; the middle value does not contradict the limit.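

No step from compound 3 to compound 4 can be read in this assay, because both compounds stand at a limit and not at a number: the limit of > 20000 nM in this assay, at which 4 of the 4 values shown sit.

The compounds shown leave open how bromo and methoxy compare on this aromatic carbon, and how strongly any of the four inhibits.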